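Methyl on the ring: a small change with a large step

The source may hold more compounds than are shown below. What is called first, only, known or untested is meant among the compounds shown, and "the series" means these compounds.

Measured compounds:
compound 1, `Cc1cccc(/C(N)=N/NC(=S)N2CCSCC2)n1`, 22.5%
compound 2, `N/C(=N\NC(=S)N1CCSCC1)c1ccccn1`, 54.3%
compound 3, `N/C(=N\NC(=S)N1CCCCC1)c1ccccn1`, 53.1%

In a functional assay on MCF7 cells (Homo sapiens) for cytotoxicity, read by MTT assay, with a stated time of 72 h, tested at 10 uM (on this read-out higher numbers stand for more inhibition of growth at the one concentration tested and lower numbers for less inhibition of growth), compound 2 gives 54.3%. Compound 1 differs from it by methyl in place of hydrogen on an aromatic carbon, and this change made a step of a number 31.8 percentage points lower from compound 2 to compound 1 (beyond the scatter). Compound 3 differs from compound 2 by piperidin-1-yl in place of thiomorpholin-4-yl on a thiocarbonyl carbon, a change that made a step of only a number 1.2 percentage points lower from compound 2 to compound 3 (within the scatter), so compound 2 and compound 3 are within scatter of each other.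

Compound 4, `Cc1ccnc(/C(N)=N/NC(=S)N2CCCCC2)c1`, has not yet been tested. It differs from compound 3 by methyl in place of hydrogen on an aromatic carbon. This is the same kind of change as that from compound 2 to compound 1, but not the same: there the methyl sits next to the ring nitrogen and meta to a large group, here it sits meta to a large group and opposite the ring nitrogen. Because the earlier step of a number 31.8 percentage points lower from compound 2 to compound 1 (beyond the scatter) was large, a loss is expected here too, but the different place makes its size uncertain; the expected step is a number 20.1 percentage points lower from compound 3 to compound 4 (beyond the scatter). Compound 4 is therefore estimated at 33%, between 15% and 50%.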

Compound 4, percent growth inhibition at one concentration: 40.7%
The estimate for compound 4 lay 7.7 percentage points below the measured number; the measured number falls inside the stated range.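

In this assay, methyl in place of hydrogen on an aromatic carbon again lowers the reading, with a step of a number 12.4 percentage points lower from compound 3 to compound 4 (beyond the scatter). The direction of the change carries over from one core to the other, but its size does not: the same change on two cores in this assay, a number 31.8 percentage points lower (beyond the scatter) from compound 2 to compound 1 and a number 12.4 percentage points lower (beyond the scatter) from compound 3 to compound 4, 19.4 percentage points apart, beyond the scatter of two such steps

This does not show what goes with the gap, since the two pairs differ both in where the methyl sits on the ring and in the group on the thiocarbonyl carbon, thiomorpholin-4-yl in compound 1 and piperidin-1-yl in compound 4. The compounds shown leave open what each methyl placement would give with the other of these two groups, which is the comparison that would separate the two differences. Also open is how an ethyl, a methoxy or a chlorine in place of the methyl would read, and whether a morpholin-4-yl on the thiocarbonyl carbon would behave as the two groups shown do.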